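Swapping the Ether Linker for an Amine

The source may hold more compounds than are shown below. What is called first, only, known or untested is meant among the compounds shown, and "the series" means these compounds.

Within the data shown here, compound 2 `CC(C)(C)NC(=O)NS(=O)(=O)c1cc(C#N)ccc1Oc1ccc(Cl)cc1` gives the higher of the two numbers measured so far in a functional assay on HEK293 cells for antagonist activity at thromboxane A2 receptor (Homo sapiens), read by fluorescence and calcium flux (a lower number here means a stronger inhibitor, a higher number a weaker inhibitor), at 5270 nM. Among the measured compounds shown here, its only measured neighbour, compound 1 `Cc1ccc(Oc2ccc(C#N)cc2S(=O)(=O)NC(=O)NC(C)(C)C)cc1`, gives 680 nM, and the one step between them is a 7.8-fold higher number from compound 1 to compound 2 (0.89 log units; beyond the scatter). Compound 3 `Cc1ccccc1Nc1ccc(C#N)cc1S(=O)(=O)NC(=O)NC(C)(C)C` differs from compound 2 by (2-methylphenyl)amino in place of 4-chlorophenoxy on an aromatic carbon. That single step bears only partly on this change, since here two parts of the group alter at once; still, it points toward a lower number. For compound 3 the expected value is 1500 nM, with a range from 400 nM to 6000 nM. This amounts to an expected step of a 3.5-fold lower number from compound 2 to compound 3 (0.55 log units; beyond the scatter).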

Compound 3, half-maximal inhibitory concentration: 4780 nM
Estimate against measurement, compound 3: 3.2-fold (0.50 log units) below, and the stated range covers the measured number.
By their numbers in this assay, from the lowest: compound 1; then compounds 3 and 2 (each within the scatter of the next).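

Putting (2-methylphenyl)amino in place of 4-chlorophenoxy leaves the two compounds indistinguishable (a 1.1-fold lower number from compound 2 to compound 3 (0.04 log units; within the scatter)), so at this position these two groups cannot be told apart. Set against 4-methylphenoxy, the same group gives a clear loss of inhibition (a 7.0-fold higher number from compound 1 to compound 3 (0.85 log units; beyond the scatter)), and 4-methylphenoxy keeps the lowest number of the three. No evidence is available to explain these results. As far as these compounds go, each step alters both the linking atom and the ring substituent, so their separate contributions stay open. A (4-methylphenyl)amino or 2-methylphenoxy group would separate the linking atom from the methyl placement.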